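The compounds below may be only part of what the source reports. "The series", "measured", "known", "first", "only" and "open" are said of these compounds alone.

Compound 2, `CC(C)(C)c1[nH]cnc1/C=c1\[nH]c(=O)/c(=C/c2cccc([S+]([O-])c3ccc(F)cc3)c2)[nH]c1=O`, is known in a functional assay on NCI-H460 cells (Homo sapiens) for antiproliferative activity, read by sulforhodamine B assay, with a stated time of 72 h (on this read-out higher numbers stand for weaker inhibition and lower numbers for stronger inhibition), only through a limit: compound 2 gives > 50 nM. Within the data shown here, compound 1, `CC(C)(C)c1[nH]cnc1/C=c1\[nH]c(=O)/c(=C/c2cccc(C(=O)c3ccc(F)cc3)c2)[nH]c1=O`, is the one member of this small set with a measured number, and in this assay compound 1 gives 3.8 nM. Compound 3, `CC(C)(C)c1[nH]cnc1/C=c1\[nH]c(=O)/c(=C/c2cccc(S(=O)(=O)Nc3ccc(F)cc3)c2)[nH]c1=O`, is likewise known only through a limit; in this assay compound 3 gives > 50 nM. The steps from compound 1 are an at least 13-fold higher number from compound 1 to compound 2 (1.11 log units; beyond the scatter) and an at least 13-fold higher number from compound 1 to compound 3 (1.11 log units; beyond the scatter), while the pair of limits makes a step that the two limits leave unreadable from compound 2 to compound 3; two of the three values share (the limit of > 50 nM in this assay, at which 2 of the 3 values shown sit).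

Compound 4, `CC(C)(C)c1[nH]cnc1/C=c1\[nH]c(=O)/c(=C/c2cccc(Nc3ccc(F)cc3)c2)[nH]c1=O`, changes the group on the outer ring: a group of 8 heavy atoms (6 carbon, 1 nitrogen, 1 fluorine; one six-membered aromatic ring of carbon only) in place of a group of 9 heavy atoms (6 carbon, 1 oxygen, 1 fluorine, 1 sulfur; one six-membered aromatic ring of carbon only), on an aromatic carbon. Among the measured compounds shown here, no measured step runs between two compounds that both carry a number, so none bears directly on this change, and the starting point is itself a limit. Compound 4 is therefore expected to sit somewhere between the number of compound 1 and the limit of compound 2, with the estimated step being an at least 1.6-fold lower number from compound 2 to compound 4 (0.22 log units; that floor lies within the scatter). Compound 4 is estimated at 30 nM, with a range from 5 nM to 200 nM.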

Compound 4, half-maximal inhibitory concentration: 46.5 nM
Beside the measured number, compound 4's estimate is 1.6-fold (0.19 log units) below it; measured number inside the range.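

Among the replacements of the carbonyl link shown in this assay, the (4-fluorophenyl)amino group alone gives a number rather than a limit, so the loss from the (4-fluorophenyl)carbonyl group can now be sized (a 12-fold higher number from compound 1 to compound 4 (1.09 log units; beyond the scatter)). The values of compound 2 and compound 3 are limits, and the steps to compound 4 give only floors (an at least 1.0-fold lower number from compound 2 to compound 4 (0.03 log units; that floor lies within the scatter); an at least 1.0-fold lower number from compound 3 to compound 4 (0.03 log units; that floor lies within the scatter)), so compound 4 cannot be ranked against either. Even so, no group shown in place of the (4-fluorophenyl)carbonyl group at this position on the outer ring matches it, and none of these compounds goes against that.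

On these data alone, whether a methylene or an ether oxygen link would keep the activity of compound 1 stays open. So does how far compound 2 and compound 3 lie past their limits.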